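The source may hold more compounds than are shown below. What is called first, only, known or untested is meant among the compounds shown, and "the series" means these compounds.

In a functional assay on PC-3 cells (Homo sapiens) for cytotoxicity, read by MTT assay, with a stated time of 72 h (on this read-out lower numbers stand for higher toxicity in this test and higher numbers for lower toxicity in this test), compound 2 `CS/C(=N\C(=O)c1ccco1)NC(=O)c1ccco1` is recorded only as a limit of the test, > 100000 nM. Compound 1 `C[Se]/C(=N\C(=O)c1ccco1)NC(=O)c1ccco1` likewise reaches just the limit in this assay, at > 100000 nM. Compound 3 `C[Se]/C(=N\C(=O)c1cc(-c2ccccc2)nc2ccccc12)NC(=O)c1cc(-c2ccccc2)nc2ccccc12` also stops at the limit, > 100000 nM. The step that the two limits leave unreadable from compound 1 to compound 2 is therefore not readable. Compound 4 `O=C(/N=C(/NC(=O)c1ccco1)[Se]Cc1ccccc1)c1ccco1` is not yet measured; it differs from compound 2 by a group of 8 heavy atoms (7 carbon, 1 selenium; one six-membered aromatic ring of carbon only) in place of a group of 2 heavy atoms (1 carbon, 1 sulfur; no ring), on a carbon with a double bond to nitrogen. Going by the values given here, no measured step bears on this change, and the limit of > 100000 nM in this assay, at which 3 of the 3 values shown sit, leaves no direction to follow. Because of the limit of > 100000 nM in this assay, at which 3 of the 3 values shown sit, compound 4 is expected to sit at the limit as well, with an estimate of 100000 nM and a range from 30000 nM to 300000 nM. The expected step of a number no higher from compound 2 to compound 4 (the limit leaves the size open) is thus one of no readable change.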

Compound 4, concentration lethal to 50% of the cells: 84800 nM
Compound 4: the middle estimate sits 1.2-fold (0.07 log units) above what was measured, and the stated range covers the measured number.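

Among the compounds shown, compound 4 alone gives a number rather than a limit in this assay, so this position can carry a group that leaves the limit. The exchange on the carbon with a double bond to nitrogen gives an at least 1.1-fold lower number from compound 2 to compound 4 (0.07 log units; that floor lies within the scatter), and phenyl in place of hydrogen on the saturated chain carbon bound to selenium gives an at least 1.1-fold lower number from compound 1 to compound 4 (0.07 log units; that floor lies within the scatter). Neither step can be sized exactly, since the other compounds offer no number to set against it: the limit of > 100000 nM in this assay, at which 3 of the 4 values shown sit.

Going by these compounds, whether a longer chain or an amine on the selenium would give a step clearly beyond the scatter stays open. So does whether a benzyl group on sulfur would match compound 4.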